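This account rests on a few compounds, and the source may have more. Where it says the series, first, only, none or still open, it means among the compounds named here.

Measured compounds in an ADME assay on MT4 cells (Homo sapiens) for cytotoxicity, read by MTT assay, with a stated time of 5 days; on this read-out higher numbers stand for lower toxicity in this test and lower numbers for higher toxicity in this test:

- Compound 1 `CCCCNc1cc(Oc2c(OC)cc3cc(C#N)ccc3c2OC)nc(Nc2ccc(C#N)cc2)n1`: compound 1 gives > 125000 nM, a limit of the assay and not a number.
- Compound 2 `COc1cc2cc(C#N)ccc2c(OC)c1Oc1cc(NC(C)(C)C)nc(Nc2ccc(C#N)cc2)n1`: compound 2 gives > 125000 nM, again a limit of the assay.
- Compound 3 `COc1cc2cc(C#N)ccc2c(OC)c1Oc1cc(NC2CC2)nc(Nc2ccc(C#N)cc2)n1`: compound 3 gives > 125000 nM, also a limit of the assay.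

Compound 3 therefore stands at the upper edge of what this assay reports, together with the other two, as the limit of > 125000 nM in this assay, at which 3 of the 3 values shown sit, records. None of the three steps can be read: a step that the two limits leave unreadable from compound 1 to compound 3, a step that the two limits leave unreadable from compound 2 to compound 3 and a step that the two limits leave unreadable from compound 1 to compound 2 all run between limits, so their sizes are not known.

Compound 4 `COc1cc2cc(C#N)ccc2c(OC)c1Oc1cc(NCC2CCOC2)nc(Nc2ccc(C#N)cc2)n1` differs from compound 3 by (oxolan-3-yl)methyl in place of cyclopropyl on a nitrogen on an aromatic ring. For the measured compounds named here, no measured step bears on this change, because every step in the set is unreadable at the limit of the limit of > 125000 nM in this assay, at which 3 of the 3 values shown sit. Within this series no substituent on that nitrogen has produced a readable value in this assay, so no step beyond the scatter is expected, and the reading of compound 4 is expected to be another limit, with a step that the limit leaves unreadable from compound 3 to compound 4 as the estimated step. Compound 4 is estimated at 150000 nM, expected between 60000 nM and 400000 nM.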

Compound 4, half-maximal cytotoxic concentration: > 125000 nM
Compound 4 was reported as a limit; the forecaster's own chance of this, stated with the estimate: 85%; the middle value is on the limit's open side.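

In this assay compound 4 gives > 125000 nM, a limit of the assay and not a number. No step from compound 1, compound 2 or compound 3 to compound 4 can be read: the limit of > 125000 nM in this assay, at which 4 of the 4 values shown sit.

Still open, going by these compounds, is whether any substituent on the nitrogen on the aromatic ring gives a readable value in this assay.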